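Acetyl in place of hydroxyethyl on the aryl arm

The source may report more compounds than this note shows. Statements on the series, on what has been measured and on what is new or still open speak of the compounds shown alone.

Going by the values given here, compound 2 `Cc1cnc(-c2ccccc2C(C)O)nc1NCc1ccc(-c2cccnc2)cc1` stands at 2000 nM in an assay on a protein complex for inhibition of ubiquitin carboxyl-terminal hydrolase 1/WD repeat-containing protein 48 (Homo sapiens), read by fluorescence (a higher number here means a weaker inhibitor, a lower number a stronger inhibitor), the highest of the two numbers in hand; the only neighbour is compound 1 `Cc1cnc(-c2ccccc2C(C)C)nc1NCc1ccc(-c2cccnc2)cc1`, which in this assay gives 70 nM. Among the compounds with values here, the single measured step between them runs a 29-fold higher number from compound 1 to compound 2 (1.46 log units; beyond the scatter), a large loss brought by a hydroxy in place of a methyl on the chain carbon. Compound 3 `CC(=O)c1ccccc1-c1ncc(C)c(NCc2ccc(-c3cccnc3)cc2)n1` is not yet measured; it differs from compound 2 by acetyl in place of 1-hydroxyethyl on an aromatic carbon. Within the data shown here, the step from compound 1 to compound 2 bears on this change only in part: the hydroxy that came in with compound 2 leaves again, but the acetyl that replaces it is not the methyl of compound 1, and no measured pair shows acetyl against either 1-hydroxyethyl or isopropyl. Because the step of a 29-fold higher number from compound 1 to compound 2 (1.46 log units; beyond the scatter) was large and compound 3 gives up the donor that arrived with it, a clearly lower number is expected for compound 3, short of a full return toward compound 1. The expected step is a 3.3-fold lower number from compound 2 to compound 3 (0.52 log units; beyond the scatter). Compound 3 is estimated at 600 nM, within a range from 150 nM to 2500 nM.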

Compound 3, half-maximal inhibitory concentration: 8700 nM
Estimate against measurement, compound 3: 15-fold (1.16 log units) below; measured number above the stated range.
By their numbers in this assay, from the lowest: compound 1; then compound 2; then compound 3.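

In this assay, acetyl in place of 1-hydroxyethyl gives a 4.4-fold higher number from compound 2 to compound 3 (0.64 log units; beyond the scatter), so giving up the hydrogen-bond donor at this aromatic carbon, with the heavy-atom count and the acceptor count unchanged, brings no recovery and the number moves further from that of the isopropyl group. The donor count therefore does not track the numbers among these three groups: the group with no donor and a carbonyl stands furthest from isopropyl, at a 120-fold higher number from compound 1 to compound 3 (2.09 log units; beyond the scatter), and the order from the lowest number runs isopropyl, 1-hydroxyethyl, acetyl for these compounds alone. Nothing measured here explains why the carbonyl group fares worse than the hydroxy-bearing group at this place.

The three groups leave open whether the losses follow the oxygen atom itself or some other difference between these groups, which a comparison with methoxy or with an all-carbon group such as ethyl, cyclopropyl or tert-butyl on the same aromatic carbon would help to separate. Also open, on these data alone, is whether an amine or a primary amide at this place would follow acetyl and 1-hydroxyethyl or stay closer to isopropyl.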